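The source may hold more compounds than are shown below. What is called first, only, known or untested is meant among the compounds shown, and "the series" means these compounds.

Measured in a functional assay on B16-F10 cells (Mus musculus) for antiproliferative activity, read by MTT assay, with a stated time of 48 h; on this read-out lower numbers stand for stronger inhibition and higher numbers for weaker inhibition:
- Compound 1 `COc1ccc(C2OC(c3ccc4ccccc4c3)=NN2C(C)=O)cc1`: 6.86 ug/mL
- Compound 2 `CC(=O)N1N=C(c2ccc3ccccc3c2)OC1c1ccc(Br)cc1`: 4.68 ug/mL
- Compound 3 `CC(=O)N1N=C(c2ccc3ccccc3c2)OC1c1cccc(F)c1`: 1.61 ug/mL

Compound 3 has the lowest number of the three in this assay, and its gaps to both others lie beyond the scatter. The next compound, compound 4 `CC(=O)N1N=C(c2ccc3ccccc3c2)OC1c1ccccn1`, keeps the shared core but carries pyridin-2-yl in place of 3-fluorophenyl on a saturated ring carbon.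

Two measured swaps at this same carbon bear on the change. They gave a 4.3-fold lower number from compound 1 to compound 3 (0.63 log units; beyond the scatter) and a 2.9-fold lower number from compound 2 to compound 3 (0.46 log units; beyond the scatter), so replacing this group has moved the number only modestly so far. The third step, a 1.5-fold lower number from compound 1 to compound 2 (0.17 log units; within the scatter), shows that a swap here can also leave the number within the scatter. Among the measured compounds shown here, none of the measured compounds carries pyridin-2-yl, so the direction remains uncertain. Compound 3, at 1.61 ug/mL, already sits lowest, so a modest rise is expected rather than a further fall. The expected change is a 1.9-fold higher number from compound 3 to compound 4 (0.27 log units; within the scatter). Compound 4 is estimated at 3 ug/mL, with an expected range of 1 ug/mL to 8 ug/mL.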

Compound 4, half-maximal inhibitory concentration: 7.18 ug/mL
For compound 4 the middle estimate is 2.4-fold (0.38 log units) below the measured one, within the range that was stated.
By their numbers in this assay, from the lowest: compound 3; then compounds 2, 1 and 4 (each within the scatter of the next).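

Swapping 3-fluorophenyl for pyridin-2-yl, the first ring here with a hetero atom at this carbon, gives a 4.5-fold higher number from compound 3 to compound 4 (0.65 log units; beyond the scatter) in this assay, so this ring does not keep the low number of compound 3. The steps to the other two are a 1.5-fold higher number from compound 2 to compound 4 (0.19 log units; within the scatter) and a 1.0-fold higher number from compound 1 to compound 4 (0.02 log units; within the scatter), both within the scatter, which leaves compounds 1, 2 and 4 indistinguishable and compound 3 alone apart from the rest. Nothing measured here offers an explanation for this step.

Still open, going by these compounds, is whether 4-fluorophenyl or 3-chlorophenyl at this carbon would match compound 3, which would show whether the fluorine or the ring position matters more. Also open, on these data alone, is whether pyridin-3-yl or pyridin-4-yl would differ from pyridin-2-yl.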